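Hydroxy removal on the second aryl ring of the pyrazoline series

The source may report more compounds than this note shows. Statements on the series, on what has been measured and on what is new or still open speak of the compounds shown alone.

Measured so far in a functional assay on HeLa cells (Homo sapiens) for antiproliferative activity, read by MTT assay, with a stated time of 48 h; a lower number here means a stronger inhibitor of growth, a higher number a weaker inhibitor of growth:
- compound 1 `COC(=O)N1N=C(c2ccccc2)CC1c1cc(OC)c(OC)c(OC)c1`: 2180 nM
- compound 2 `COC(=O)N1N=C(c2cccc(O)c2)CC1c1cc(OC)c(OC)c(OC)c1`: 1970 nM
- compound 3 `COC(=O)N1N=C(c2ccccc2)CC1c1ccc(OC)c(O)c1`: 7520 nM

Compound 3 stands highest of the three, beyond the scatter from both others. How the cores of compound 2 and compound 3 differ is not broken down here.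

The step from compound 2 to compound 1 is hydrogen in place of hydroxy on an aromatic carbon, and it gave a 1.1-fold higher number from compound 2 to compound 1 (0.04 log units; within the scatter).

Compound 4 `COC(=O)N1N=C(c2ccccc2)CC1c1ccc(OC)cc1` is not yet measured. It differs from compound 3 by hydrogen in place of hydroxy on an aromatic carbon. This is the same kind of change as from compound 2 to compound 1, not the same: in compound 3 the place is ortho to a methoxy group, which is not so in compound 2.

In this assay the step from compound 3 to compound 4 is expected to be about a 1.1-fold higher number from compound 3 to compound 4 (0.03 log units; within the scatter), near the earlier one, because that step gave a 1.1-fold higher number from compound 2 to compound 1 (0.04 log units; within the scatter). The expected value for compound 4 is 8000 nM, with a range from 3000 nM to 20000 nM.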

Compound 4, concentration for 50% growth inhibition: 12700 nM
Estimate against measurement, compound 4: 1.6-fold (0.20 log units) below; the measured number falls inside the stated range.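

In this assay, hydrogen in place of hydroxy, at a place ortho to a methoxy group, gave a 1.7-fold higher number from compound 3 to compound 4 (0.23 log units; within the scatter). Set beside the earlier step, the change carries from one core to the other with no difference that can be told apart: the same change on two cores in this assay, a 1.1-fold higher number (0.04 log units; within the scatter) from compound 2 to compound 1 and a 1.7-fold higher number (0.23 log units; within the scatter) from compound 3 to compound 4, 1.5-fold (0.18 log units) apart, within the scatter of two such steps

This supports only a narrow reading: on these two cores, removing the hydroxy leaves the number within the scatter, although the place is ortho to a methoxy group only in compound 3. It rests on two pairs in a single assay, so it does not show that the result extends to other cores, to other places on these rings or to other assays, and it does not explain why the hydroxy matters so little here.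

The compounds shown leave open what an amine or a carboxylic acid would do at the place held by the hydroxy. They also leave open whether an ethoxy group or a longer chain in place of the neighbouring methoxy group would change the outcome of the same step.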